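The compounds below may be only part of what the source reports. "The series", "measured", "known", "first", "only" and "open" are said of these compounds alone.

Measured in a physicochemical assay for solubility, with a stated time of 4 h, at pH 2.0; a higher number here means a more soluble compound, a lower number a less soluble compound:
- compound 1 `Cc1cc(/C=C/C#N)cc(C)c1Oc1cc(Nc2ccc(C#N)cc2)c(N)cc1C(N)=O`: 2.09 ug/mL
- compound 2 `COC(=O)c1cc(N)c(Nc2ccc(C#N)cc2)cc1Oc1c(C)cc(CCC#N)cc1C`: 21.8 ug/mL
- compound 3 `Cc1cc(C#N)cc(C)c1Oc1cc(Nc2ccc(C#N)cc2)c(N)cc1C(F)(F)F`: 0.96 ug/mL

Compound 1, at 2.09 ug/mL, holds the middle place among these three numbers. Compound 3 gives the lower reading of 0.96 ug/mL, and compound 2 gives the higher reading of 21.8 ug/mL. Both gaps from compound 1 lie beyond the usual scatter of this assay, the wider one being the gap to compound 2.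

The next compound to be read is compound 4 `CNC(=O)c1cc(N)c(Nc2ccc(C#N)cc2)cc1Oc1c(C)cc(/C=C/C#N)cc1C`. It departs from compound 1 by one change: methyl in place of hydrogen on an amide-type nitrogen. In words, this is methyl in place of hydrogen on an amide-type nitrogen, or carbamoyl to methylcarbamoyl.

For the measured compounds named here, no pair of measured compounds differs in a single place, so the three values do not show what this change does in this assay. Compounds 2 and 3 differ from compound 1 in more than one place and offer only a rough spread of values. The expectation therefore starts from compound 1 at 2.09 ug/mL and foresees no step beyond the scatter, with no firm direction.

The expected step is a 1.2-fold higher number from compound 1 to compound 4 (0.08 log units; within the scatter).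

For compound 4 the estimated value is 2.5 ug/mL, with an expected range from 0.9 ug/mL to 7 ug/mL.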

Compound 4, solubility: 8.63 ug/mL
Compound 4: middle estimate off by 3.5-fold (0.54 log units), on the low side, and the stated range ends below it.
By their numbers in this assay, from the lowest: compound 3; then compound 1; then compound 4; then compound 2.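

For the compounds shown here, the step of a 4.1-fold higher number from compound 1 to compound 4 (0.62 log units; beyond the scatter) in this assay is the first reading in this set that isolates a single change, since the earlier compounds differed from one another in more than one place and gave only a spread of values. It shows that the amide-type nitrogen of compound 1 is a place where methyl in place of hydrogen, with the rest of the structure held fixed, moves the reading upward by more than the usual scatter. The data offer no measurement that accounts for this step, so its cause remains unexplained.

The compounds shown leave open whether a larger group on the same nitrogen, such as an ethyl group, a second methyl or a longer chain ending in an amine, would extend this rise, lessen it or reverse it. As far as these compounds go, the finding also rests on one pair, so whether carbamoyl to methylcarbamoyl gives a step of similar size and direction when the core of compound 1 is altered elsewhere remains unknown.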